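From cyclobutyl to naphthalen-2-yl: a solubility question

The compounds below may be only part of what the source reports. "The series", "measured", "known", "first", "only" and "open" are said of these compounds alone.

Compound 1 `CC(=O)N1CCN(C(=O)N2Cc3c(NC(=O)c4ccc(F)cc4)n[nH]c3C2(C)C)CC1`: > 225000 nM, a limit in a physicochemical assay for solubility, at pH 7; on this read-out higher numbers stand for higher solubility and lower numbers for lower solubility
Compound 2 `CN1CCC(C(=O)N2Cc3c(NC(=O)C4CCC4)n[nH]c3C2(C)C)CC1`: > 225000 nM, a limit in this assay

Compound 2 gives no exact number, only (the limit of > 225000 nM in this assay, at which 2 of the 2 values shown sit). Compound 3 `CN1CCC(C(=O)N2Cc3c(NC(=O)c4ccc5ccccc5c4)n[nH]c3C2(C)C)CC1` keeps the core of compound 2 and changes one group: naphthalen-2-yl in place of cyclobutyl on a carbonyl carbon. In words, naphthalen-2-yl stands in place of cyclobutyl on a carbonyl carbon. Among the compounds with values here, no measured pair of compounds shows a comparable step, so the expectation rests on the structural change alone. A fall beyond the usual scatter is expected in this assay, with an estimated at least 4.5-fold lower number from compound 2 to compound 3 (0.65 log units; beyond the scatter). Compound 3 is expected at 50000 nM, with an estimated range of 8000 nM to 225000 nM.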

Compound 3, solubility: 219000 nM
Estimate against measurement, compound 3: 4.4-fold (0.64 log units) below, within the range that was stated.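

In this assay, compound 3 gives 219000 nM, the first exact number among these compounds. Compound 2 has only a limit, > 225000 nM. Going by these compounds, the comparison therefore gives only an at least 1.0-fold lower number from compound 2 to compound 3 (0.01 log units; that floor lies within the scatter), so placing naphthalen-2-yl instead of cyclobutyl on this carbonyl carbon has no demonstrated effect, and the true size of the step remains unknown.

Still open, on these data alone, is how a naphthalen-2-yl ring bearing an amine or a carboxylic acid would read in this assay. A longer carbon chain on this carbonyl carbon is equally uncharted.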